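The compounds below may be only part of what the source reports. "The series", "measured", "known", "first", "only" and "open" are said of these compounds alone.

Within the data shown here, in a functional assay on BT-474 cells (Homo sapiens) for cytotoxicity, with a stated time of 72 h (a lower number here means a stronger inhibitor, a higher number a weaker inhibitor), only two compounds have numbers so far. Compound 1 (`Oc1ccc(CNC2(c3ccccc3F)CCCC2)cc1CN1CCCCC1`) gives 35600 nM, and compound 2 (`Fc1ccccc1C1(NCc2cccc(CN3CCCCC3)c2)CCCC1`) gives 40000 nM, which places the two level with each other, within the scatter. Among the measured compounds shown here, the one measured step, a 1.1-fold higher number from compound 1 to compound 2 (0.05 log units; within the scatter), is the swap of hydrogen in place of hydroxy on an aromatic carbon.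

Compound 3 (`CN1CCC(Cc2cccc(CNC3(c4ccccc4F)CCCC3)c2)CC1`) has not yet been measured. It differs from compound 2 by 1-methylpiperidin-4-yl in place of piperidin-1-yl on a saturated chain carbon bound to an aromatic carbon, in words 1-methylpiperidin-4-yl in place of piperidin-1-yl on a saturated chain carbon bound to an aromatic carbon. For the measured compounds named here, no measured step involves this change, so the step between compound 1 and compound 2 bears on it only loosely, as the sole evidence of how far a single change has moved the number here. The data give no direction, and no shift beyond the scatter is expected in this assay. The expected step is a 1.3-fold lower number from compound 2 to compound 3 (0.10 log units; within the scatter). Compound 3 is estimated at 32000 nM, with an expected range from 13000 nM to 65000 nM.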

Compound 3, half-maximal inhibitory concentration: 15500 nM
Beside the measured number, compound 3's estimate is 2.1-fold (0.31 log units) above it; measured number inside the range.
By their numbers in this assay, from the lowest: compound 3; then compounds 1 and 2 (each within the scatter of the next).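

In this assay, among these compounds, the change from piperidin-1-yl to 1-methylpiperidin-4-yl on a saturated chain carbon bound to an aromatic carbon produces the only step so far that lies beyond the scatter: a 2.6-fold lower number from compound 2 to compound 3 (0.41 log units; beyond the scatter). Among the compounds shown here, the earlier swap of hydrogen for hydroxy on an aromatic carbon stayed within the scatter (a 1.1-fold higher number from compound 1 to compound 2 (0.05 log units; within the scatter)), so this position is the first to show that the number can respond to a change, although the step is modest and compound 3 still gives 15500 nM. No supporting evidence is available to explain this shift.

The step from compound 2 to compound 3 changes both how the ring is attached and whether it carries a methyl, so the compounds shown cannot assign the shift to either alteration; a piperidin-4-yl group without the methyl would separate the two. Going by these compounds, it also remains open whether the shift would extend to a larger group such as 1-ethylpiperidin-4-yl, or whether a hydroxy on the aromatic carbon would matter alongside 1-methylpiperidin-4-yl.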